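Methoxy for chloro on a core inactive at the assay limit

A few compounds are considered here, and "the series" means these few. Any claim that something is new, unique, unknown or untested is made for them only; others in the source may bear on it.

In a functional assay on CHO cells for antagonist activity at adenosine receptor A2b (Homo sapiens), read by cAMP accumulation, with a stated time of 10 min (on this read-out lower numbers stand for stronger inhibition and higher numbers for weaker inhibition), compound 2 `Cc1nc(NC(=O)c2ccc(Cl)cc2)c2nc(-c3ccccc3)sc2n1` gives only a limit, > 30000 nM, not a number. Compound 1 `Cc1nc(NC(=O)c2ccccc2)c2nc(-c3ccccc3)sc2n1` likewise gives only a limit in this assay, > 30000 nM. Within the data shown here, the one measured step, a step that the two limits leave unreadable from compound 1 to compound 2, is therefore unreadable in size, and both values sit at the limit of > 30000 nM in this assay, at which 2 of the 2 values shown sit. Compound 3 `COc1ccc(C(=O)Nc2nc(C)nc3sc(-c4ccccc4)nc23)cc1` differs from compound 2 by methoxy in place of chloro on an aromatic carbon. Among the measured compounds shown here, no measured step bears on this change beyond the unreadable one, and since the two compounds already measured both rest at the limit, there is no basis for expecting a move in this assay in either direction beyond the scatter. Compound 3 is thus expected to remain at or near the limit, with an estimated step of a number no higher from compound 2 to compound 3 (the limit leaves the size open). The estimate for compound 3 is 30000 nM, ranging from 10000 nM to 100000 nM.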

Compound 3, half-maximal inhibitory concentration: > 30000 nM
Compound 3 gave a limit, no number; the forecaster's own chance of this, stated with the estimate: 80%; the middle value lies on the limit itself.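

In this assay, among these compounds, compound 3 gives only a limit, > 30000 nM, so no step from compound 1 or compound 2 to compound 3 can be read. The compounds shown leave open whether hydrogen, chloro or methoxy at that place makes any difference in this assay, with every value resting on one limit: the limit of > 30000 nM in this assay, at which 3 of the 3 values shown sit.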